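This account rests on a few compounds, and the source may have more. Where it says the series, first, only, none or still open, it means among the compounds named here.

In a functional assay on CHO-K1 cells for antagonist activity at adenosine receptor A1 (Homo sapiens), read by a beta-galactosidase reporter and cAMP accumulation, with stated times of 15 min and 6 h (on this read-out higher numbers stand for weaker inhibition and lower numbers for stronger inhibition), two compounds have been measured so far. Compound 1 `CCc1ccc(-c2nc(N)c3cc(Cc4ccccc4)sc3n2)o1` gives 223 nM in this assay, and compound 2 `Nc1nc(-c2ccccc2)nc2sc(Cc3ccccc3)cc12` gives 151 nM. The two differ in one group only, and the step of a 1.5-fold lower number from compound 1 to compound 2 (0.17 log units; within the scatter) shows that the two numbers lie within the scatter of each other, so no real difference between them can be claimed on this evidence.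

Compound 3 `N#Cc1cccc(-c2nc(N)c3cc(Cc4ccccc4)sc3n2)n1` has not yet been measured in this assay. The change from compound 2 is 6-cyanopyridin-2-yl in place of phenyl on an aromatic carbon. Among the measured compounds shown here, the only measured step that bears on this position is the one from compound 1 to compound 2, which swapped the group on this same carbon and stayed within the scatter. With a single such comparison, the expectation for compound 3 is a step of a 1.3-fold higher number from compound 2 to compound 3 (0.12 log units; within the scatter), that is, nothing clearly beyond the scatter in either direction. Compound 3 is therefore estimated at 200 nM in this assay, with a likely range from 60 nM to 700 nM.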

Compound 3, inhibition constant: > 1000 nM
Compound 3 ended at the assay's limit; the forecaster's own chance of this, stated with the estimate: 5%; at least 5.0-fold (0.69 log units) between middle value and limit.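

In this assay compound 3 gives > 1000 nM, which is a limit of the assay and not a number. The aromatic carbon between two ring nitrogen atoms is therefore not indifferent to the group it carries: 6-cyanopyridin-2-yl in place of phenyl gives an at least 6.6-fold higher number from compound 2 to compound 3 (0.82 log units; beyond the scatter), and 6-cyanopyridin-2-yl in place of 5-ethylfuran-2-yl gives an at least 4.4-fold higher number from compound 1 to compound 3 (0.65 log units; beyond the scatter), both beyond the scatter, whereas the exchange of 5-ethylfuran-2-yl and phenyl stayed within it. Both new steps are only lower bounds, because the true number for compound 3 is hidden behind the assay's ceiling: the limit of > 1000 nM in this assay, at which 1 of the 3 values shown sits.

Whether the ring nitrogen or the nitrile goes with this rise stays open, as no compound shown has one without the other; a plain pyridin-2-yl or a 3-cyanophenyl group on this carbon would separate the two. Also open, from the compounds shown here alone, is how the rest of the shared core responds, since the amino group is the same in all three compounds and the effect of a methylamino group or a longer chain in its place cannot be told from them.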